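A few compounds are considered here, and "the series" means these few. Any claim that something is new, unique, unknown or untested is made for them only; others in the source may bear on it.

Of the compounds shown here, three have so far been measured in an assay on U2OS cells for activation of nuclear factor erythroid 2-related factor 2 (Homo sapiens), read by beta-arrestin recruitment, with a stated time of 6 h; a lower number here means that less compound is needed, a higher number that more compound is needed for the effect. Compound 1 `O=S(=O)(/C=C/c1ccc(Cl)cn1)c1cccc(F)c1` gives 2500 nM in this assay, and compound 2 `O=S(=O)(/C=C/c1ccc(Cl)cn1)c1cccc(Cl)c1` gives 1510 nM. These two differ in a single place: chloro in place of fluoro on an aromatic carbon. The step of a 1.7-fold lower number from compound 1 to compound 2 (0.22 log units; within the scatter) is a small one. Compound 3 `O=S(=O)(/C=C/c1ncccc1F)c1ccc(Cl)cc1` is built from the same atoms as compound 1, joined differently, and the difference between the two cores is not broken down here. In this assay compound 3 gives 286 nM, the lowest of the three numbers, beyond the scatter from both compound 2 and compound 1. Compound 4 `O=S(=O)(/C=C/c1ncccc1Cl)c1ccc(Cl)cc1` has not yet been measured. It differs from compound 3 in one place: chloro in place of fluoro on an aromatic carbon. Going by the values given here, this is the same kind of change as the one from compound 1 to compound 2, but not the same: there the place was on a six-membered aromatic ring of carbon only, meta to a large group, while here it is on a six-membered aromatic ring with 1 nitrogen, ortho to a large group, two atoms from the ring nitrogen. Because the earlier step of a 1.7-fold lower number from compound 1 to compound 2 (0.22 log units; within the scatter) stayed within the scatter, the expected step is a 1.4-fold lower number from compound 3 to compound 4 (0.16 log units; within the scatter). In this assay compound 4 is estimated at 200 nM, with a likely range from 70 nM to 600 nM.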

Compound 4, half-maximal effective concentration: 65 nM
Beside the measured number, compound 4's estimate is 3.1-fold (0.49 log units) above it, outside the stated range (below it).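

In this assay, putting chloro in place of fluoro gives a 4.4-fold lower number from compound 3 to compound 4 (0.64 log units; beyond the scatter), a step that stands clear of the usual scatter, whereas the same change on the core of compound 1 stayed within it. Even so, the two steps cannot be told apart, and the data give no ground for saying that the core alters what this change does: the same change on two cores in this assay, a 1.7-fold lower number (0.22 log units; within the scatter) from compound 1 to compound 2 and a 4.4-fold lower number (0.64 log units; beyond the scatter) from compound 3 to compound 4, 2.7-fold (0.42 log units) apart, within the scatter of two such steps. With only two cores, on which the change sits in different places, neither a dependable carry-over to further cores nor a true difference between these two is shown.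

The compounds shown leave open how a bromo, a methyl or a methoxy group at the same place on the core of compound 3 would compare with the chloro of compound 4. They also leave open whether an amine or a carboxylic acid at that place would keep the number as low in this assay.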